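The compounds below may be only part of what the source reports. "The series", "measured", "known", "first", "only" and "open" are said of these compounds alone.

Compound 1 `CCN/C(SC)=C(/C#N)C(=O)Nc1ccc(OCC)cc1`, compound 2 `C=CCN/C(SC)=C(/C#N)C(=O)Nc1ccc(OCC)cc1` and compound 3 `C=CCNc1[nH]nc(N)c1C(=O)Nc1ccc(OCC)cc1` have all been run in an ADME assay on TERT-RPE1 cells (Homo sapiens) for cytotoxicity, read by resazurin assay, with a stated time of 48 h; on this read-out lower numbers stand for stronger inhibition and higher numbers for weaker inhibition. Compound 1 gives only a limit of the assay, > 100000 nM. Compound 2 likewise gives only a limit, > 100000 nM. Compound 3 too gives only a limit, > 100000 nM. Each of the three rests at the limit of > 100000 nM in this assay, at which 3 of the 3 values shown sit, so no number is known for any of them.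

Compound 1 differs from compound 2 by methyl in place of vinyl on a saturated chain carbon bound to an amine nitrogen, and the step that the two limits leave unreadable from compound 2 to compound 1 is unreadable, both values being limits. Compound 3 carries a different core from compound 2; the difference between the two cores is not broken down here. Compound 4 `CCNc1[nH]nc(N)c1C(=O)Nc1ccc(OCC)cc1` has not yet been measured in this assay and differs from compound 3 by methyl in place of vinyl on a saturated chain carbon bound to a nitrogen on an aromatic ring. This is the same kind of change as that from compound 2 to compound 1, though here the saturated chain carbon is bound to a nitrogen on an aromatic ring rather than to an amine nitrogen. The earlier step offers no size to lean on. The expected step from compound 3 to compound 4 is estimated as a step that the limit leaves unreadable from compound 3 to compound 4. Compound 4 is expected to give 150000 nM in this assay because every measured compound sits at the limit of > 100000 nM in this assay, at which 3 of the 3 values shown sit.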

Compound 4, half-maximal inhibitory concentration: > 100000 nM
Compound 4 was reported as a limit; the forecaster's own chance of this, stated with the estimate: 85%; the middle value does not contradict the limit.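

Compound 3 and compound 4 both rest at a limit in this assay, so no new step can be read between them: the limit of > 100000 nM in this assay, at which 4 of the 4 values shown sit.

The compounds shown leave open how allyl and ethyl compare on either core, and at what concentration, if any, a compound of this set would reach half-maximal inhibition in this assay.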